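The compounds below may be only part of what the source reports. "The series", "measured", "known", "first", "only" and "open" are said of these compounds alone.

In an ADME assay on HepG2 cells (Homo sapiens) for cytotoxicity, with a stated time of 72 h (a higher number here means that more compound is needed for the effect, a lower number that less compound is needed), compound 1 `CC(=O)c1ccc(NC(=O)Nc2cc(C)nc3ccccc23)cc1` gives 19000 nM. Compound 2 `Cc1cc(NC(=O)Nc2ccc(C(N)=O)cc2)c2ccccc2n1`, which shares its core, gives > 25000 nM. That value is a limit of the assay and not a number, so the standing of compound 2 is known only as a limit.

Compound 3 `Cc1cc(NC(=O)Nc2ccc(C(=O)O)cc2)c2ccccc2n1` follows from compound 2 through one change: hydroxy in place of amino on a carbonyl carbon. This places hydroxy in place of amino on a carbonyl carbon, or, cut one bond further out, carbamoyl to carboxy. Among the measured compounds shown here, only one measured step bears on this carbonyl carbon, the change of methyl to amino, and it gave an at least 1.3-fold higher number from compound 1 to compound 2 (0.11 log units; that floor lies within the scatter). Going by these compounds, that step is a floor, so its full size remains unknown, and it involves neither the same departing group nor the same incoming one. It offers no firm direction, and no step beyond the scatter is expected in this assay. The expected change is a step that the limit leaves unreadable from compound 2 to compound 3. Like compound 2, compound 3 may be reported only as a limit. For compound 3 the estimated value is 30000 nM, with an expected range from 14000 nM to 60000 nM.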

Compound 3, half-maximal effective concentration: > 25000 nM
Compound 3 gave a limit, no number (the forecaster's own chance of this, stated with the estimate: 70%); the middle value is on the limit's open side.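

In this assay compound 3, which carries hydroxy on the carbonyl carbon, gives > 25000 nM, and this is a limit of the assay and not a number. Hydroxy in place of methyl at this place gives an at least 1.3-fold higher number from compound 1 to compound 3 (0.11 log units; that floor lies within the scatter), so a second group now shows a floor of the same size as amino, and neither floor establishes a change beyond the scatter. The step between compound 2 and compound 3 cannot be read, because both values stop at the same limit, and the data therefore cannot separate hydroxy from amino: the limit of > 25000 nM in this assay, at which 2 of the 3 values shown sit.

Going by these compounds, what remains open is how far compound 2 and compound 3 truly lie from compound 1, and whether either differs from it by more than the scatter. On these data alone, it is also open whether a methyl ester, an amine or a longer chain on this carbonyl carbon would give a readable number in this assay and so show how much this place matters.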